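Swapping a trimethoxyphenyl for a plain phenyl

This account rests on a few compounds, and the source may have more. Where it says the series, first, only, none or still open, it means among the compounds named here.

Compound 2 `COc1cc(-c2nc(SCc3cn(CC(=O)NC(=O)Nc4ccccn4)nn3)nc(Nc3ccc(C)cc3)c2C#N)cc(OC)c1OC` gives the lowest number of the three measured compounds in a functional assay on MCF7 cells (Homo sapiens) for inhibition, read by MTT assay, with a stated time of 72 h (a lower number here means a stronger inhibitor, a higher number a weaker inhibitor), at 21000 nM. Compound 1 `COc1cc(-c2nc(SCc3cn(CC(=O)NC(=O)Nc4ccccn4)nn3)nc(Nc3ccc(C(C)C)cc3)c2C#N)cc(OC)c1OC` gives 30900 nM and compound 3 `COc1cc(-c2nc(SCc3cn(CC(=O)NC(=O)Nc4ccccn4)nn3)nc(Nc3cccc(Cl)c3)c2C#N)cc(OC)c1OC` gives 24000 nM; the steps of a 1.5-fold lower number from compound 1 to compound 2 (0.17 log units; within the scatter), a 1.3-fold lower number from compound 1 to compound 3 (0.11 log units; within the scatter) and a 1.1-fold higher number from compound 2 to compound 3 (0.06 log units; within the scatter) all fall within the scatter, so the three stand level. Compound 4 `Cc1ccc(Nc2nc(SCc3cn(CC(=O)NC(=O)Nc4ccccn4)nn3)nc(-c3ccccc3)c2C#N)cc1` differs from compound 2 by phenyl in place of 3,4,5-trimethoxyphenyl on an aromatic carbon. Within the data shown here, none of the measured steps touches this part of the shared core, so there is no measured step to anchor the expectation, and the change must be judged on its own. Compound 4 is therefore estimated near the level of compound 2, with a wide range, at 30000 nM (from 8000 nM to 100000 nM), an expected step of a 1.4-fold higher number from compound 2 to compound 4 (0.15 log units; within the scatter).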

Compound 4, half-maximal inhibitory concentration: > 64000 nM
Compound 4: only a limit was reported; the forecaster's own chance of this, stated with the estimate: 15%; middle value at least 2.1-fold (0.32 log units) away from the limit.
By their numbers in this assay, from the lowest: compounds 2, 3 and 1 (each within the scatter of the next). At a limit, above all of these: compound 4.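

Compound 1, compound 2 and compound 3 differ only in the aryl group on the amino nitrogen, and they stand level. Among these compounds, changing the aromatic carbon next to the ring nitrogen from 3,4,5-trimethoxyphenyl to phenyl gives an at least 3.0-fold higher number from compound 2 to compound 4 (0.48 log units; beyond the scatter), the only step here beyond the scatter, so in this assay this position matters more than the varied aryl group. The result for compound 4 is a limit, not a number: the limit of > 64000 nM in this assay, at which 1 of the 4 values shown sits.

From the compounds shown here alone, the full size of the step stays open. So does whether a single methoxy group, a hydroxyl or an amine on that phenyl would hold the level of compound 2.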